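A few compounds are considered here, and "the series" means these few. Any claim that something is new, unique, unknown or untested is made for them only; others in the source may bear on it.

Working notes on the series.

Compound 1 `O=C1Nc2ccc(Cl)cc2/C1=C\c1c(Cl)n(CCCc2ccccc2)c2ccccc12` is the chloro-bearing member of the pair measured so far. In a functional assay on cells (Cancer cell lines, Homo sapiens) for cytotoxicity, with a stated time of 48 h (on this read-out lower numbers stand for stronger inhibition of growth and higher numbers for weaker inhibition of growth), compound 1 gives 2820 nM. Compound 2 `O=C1Nc2ccccc2/C1=C\c1c(Cl)n(CCCc2ccccc2)c2ccccc12` differs from it only by hydrogen in place of chloro on an aromatic carbon, and in this assay compound 2 gives 16600 nM. For the measured compounds named here, that change reads as a 5.9-fold higher number from compound 1 to compound 2 (0.77 log units; beyond the scatter), so compound 2 stands as the higher of the two numbers measured so far, with compound 1 as its only neighbour.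

Compound 3 `O=C1Nc2ccccc2/C1=C\c1c(Cl)n(Cc2ccccc2)c2ccccc12` is the next step from compound 2. The change is phenyl in place of phenethyl on a saturated chain carbon bound to an aromatic nitrogen. Going by the values given here, the one measured step in the set, from compound 1 to compound 2, concerns the chloro on the aromatic carbon and does not touch the chain bound to the aromatic nitrogen, so nothing measured bears directly on the step to compound 3. Among the compounds with values here, with no step to lean on, the expectation for compound 3 in this assay is a number close to that of compound 2, an estimated step of a 1.0-fold lower number from compound 2 to compound 3 (0.02 log units; within the scatter), not beyond the scatter in either direction, with the range kept wide. Compound 3 is therefore estimated at 16000 nM, between 5000 nM and 50000 nM.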

Compound 3, concentration for 50% growth inhibition: 16600 nM
Compound 3: the middle estimate sits 1.0-fold (0.02 log units) below what was measured, within the range that was stated.
By their numbers in this assay, from the lowest: compound 1; then compounds 2 and 3 (each within the scatter of the next).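

In this assay, for the compounds shown here, the step on the chain bound to the aromatic nitrogen reads no change at the digits printed from compound 2 to compound 3 (within the scatter), which gives the first reading at this position: with the rest of the molecule held fixed, the 3-phenylpropyl and benzyl forms are not told apart. The earlier step on the aromatic carbon, a 5.9-fold higher number from compound 1 to compound 2 (0.77 log units; beyond the scatter), lay beyond the scatter, so across these three compounds the chloro change shifts the number while the chain change does not, a contrast that rests on one step at each place. Nothing measured on these compounds bears on why the number holds when the chain changes.

From the compounds shown here alone, both chains compared here carry a phenyl ring, so a chain ending in an amine or a carboxylic acid, or a plain alkyl chain with no ring, remains open at this position. Going by these compounds, the chain step is also read only on the core of compound 2, which has hydrogen in place of the chloro of compound 1, so whether benzyl and 3-phenylpropyl also match on the chloro-bearing core remains open.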